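The compounds below may be only part of what the source reports. "The series", "measured", "known", "first", "only" and "open" are said of these compounds alone.

Measured compounds:
- compound 1, `COc1cc(C/N=C(\S)NCc2ccc(C(C)(C)C)cc2)ccc1OS(C)(=O)=O`: 300 nM
- compound 2, `CCS(=O)(=O)Nc1ccc(C/N=C(\S)NCc2ccc(C(C)(C)C)cc2)cc1`: 1300 nM
- compound 3, `CC(C)(C)c1ccc(C/N=C(\S)NCc2ccc(NS(=O)(=O)Cc3ccccc3)cc2)cc1`: 1500 nM

All three share a thiourea core carrying a tert-butylbenzyl arm. In a functional assay for antagonist activity at Vanilloid receptor (Rattus norvegicus) (on this read-out lower numbers stand for stronger inhibition and higher numbers for weaker inhibition), compound 2 gives 1300 nM, which places it second highest of the three numbers. Compound 3 gives 1500 nM, and the gap between compound 2 and compound 3 lies within the scatter, so the two are read as equivalent. Compound 1 gives 300 nM, a lower number than compound 2 by a margin beyond the scatter.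

Compound 4, `CNS(=O)(=O)Nc1ccc(C/N=C(\S)NCc2ccc(C(C)(C)C)cc2)cc1`, is not yet measured in this assay. It differs from compound 2 in one place: methylamino in place of ethyl on a sulfonyl sulfur. Among the measured compounds shown here, no measured pair in this set isolates this kind of change, so no step size is available from the data. The change is small in count and leaves the sulfonamide nitrogen and the rest of the molecule untouched; the step from compound 2 to compound 4 is therefore expected to fall within the scatter, with no direction favoured, as a 1.2-fold higher number from compound 2 to compound 4 (0.06 log units; within the scatter). On that basis compound 4 is estimated at 1500 nM in this assay, with a range from 500 nM to 4500 nM.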

Compound 4, half-maximal inhibitory concentration: 2500 nM
Beside the measured number, compound 4's estimate is 1.7-fold (0.22 log units) below it; measured number inside the range.
By their numbers in this assay, from the lowest: compound 1; then compounds 2, 3 and 4 (each within the scatter of the next).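

In this assay, among the compounds shown here, methylamino in place of ethyl on a sulfonyl sulfur gives a 1.9-fold higher number from compound 2 to compound 4 (0.28 log units; within the scatter), the first step that isolates a change in one place. Compound 2 and compound 4 therefore read as equivalent, so this position accepts a methylamino group, with its hydrogen-bond donor, as well as an ethyl group, which has none. No available measurement bears on the reason for this outcome.

On these data alone, it remains open whether a dimethylamino group, with no hydrogen on its nitrogen, or a longer chain such as butyl on the same sulfonyl sulfur would also stay within the scatter of compound 2. Since this is a single pair, it is also unknown whether the same change would read alike elsewhere in the series.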